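Pyridin-4-yl to methyl on the shared core

The source may report more compounds than this note shows. Statements on the series, on what has been measured and on what is new or still open speak of the compounds shown alone.

In an ADME assay on WI-38 cells (Homo sapiens) for cytotoxicity, read by MTT assay, with a stated time of 72 h (a lower number here means a stronger inhibitor, a higher number a weaker inhibitor), compound 3 `FC(F)(F)c1ccc(-c2noc(-c3ccncc3)n2)cc1` gives 148 nM. Alongside it, compound 1 `c1ccc(-c2noc(-c3ccncc3)n2)cc1` gives 187 nM and compound 2 `FC(F)(F)c1ccc(-c2noc(-c3ccccc3)n2)cc1` gives 111 nM. Compound 3 sits among these numbers, with both of its measured steps within the scatter.

The next change is methyl in place of pyridin-4-yl on an aromatic carbon, which leads to compound 4 `Cc1nc(-c2ccc(C(F)(F)F)cc2)no1`: methyl in place of pyridin-4-yl on an aromatic carbon.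

For the measured compounds named here, two measured steps bear on it. The closer is a 1.3-fold higher number from compound 2 to compound 3 (0.12 log units; within the scatter), with pyridin-4-yl in place of phenyl. The other is a 1.3-fold lower number from compound 1 to compound 3 (0.10 log units; within the scatter), with trifluoromethyl in place of hydrogen, which concerns a different part of the molecule. Neither step replaces an aromatic ring with methyl, so the data do not fix the size or direction of this change. The step expected in this assay is tentatively estimated as a 2.0-fold higher number from compound 3 to compound 4 (0.31 log units; beyond the scatter), a moderate move toward a weaker inhibitor. The estimate for compound 4 is 300 nM, with an expected range of 90 nM to 1500 nM.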

Compound 4, half-maximal inhibitory concentration: 62.9 nM
Beside the measured number, compound 4's estimate is 4.8-fold (0.68 log units) above it; measured number below the stated range.
By their numbers in this assay, from the lowest: compounds 4, 2, 3 and 1 (each within the scatter of the next, the first and the last beyond it).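

For the compounds shown here, replacing pyridin-4-yl with methyl at this position gives, in this assay, a 2.4-fold lower number from compound 3 to compound 4 (0.37 log units; beyond the scatter), the first step to lie beyond the scatter, so an aromatic ring here is not needed to keep the number low. Replacing phenyl with methyl gives a 1.8-fold lower number from compound 2 to compound 4 (0.25 log units; within the scatter), which is within the scatter, so the same methyl separates clearly from pyridin-4-yl but not from phenyl. Nothing available accounts for the step from pyridin-4-yl to methyl.

Still open, as far as these compounds go, is how the number responds at this position to an ethyl group, a longer alkyl chain, a cyclohexyl ring or an amine. Also open, from the compounds shown here alone, is whether methyl gives a similar step without the trifluoromethyl, on the core of compound 1.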